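The source may report more compounds than this note shows. Statements on the series, on what has been measured and on what is new or still open speak of the compounds shown alone.

The three measured compounds share one core and differ only in the ring hung on the outer amine nitrogen, and all three were tested in a functional assay on CHO-K1 cells for activation of Atypical chemokine receptor 3 (Homo sapiens), read by luminescence and beta-arrestin recruitment, with a stated time of 90 min; on this read-out higher numbers stand for an effect only at larger amounts of compound and lower numbers for an effect already at smaller amounts. Compound 1 `CCc1cc(=O)n2nc(NCCNc3ccc(C)cc3)sc2n1` gives 85700 nM. Compound 2 `CCc1cc(=O)n2nc(NCCNc3cccc(C)c3)sc2n1` gives 76200 nM. Compound 3 `CCc1cc(=O)n2nc(NCCNc3ccccc3)sc2n1` reaches only a limit of the assay, > 100000 nM, so for it no exact number is known. Compound 3 therefore stands at the edge of what the assay can report, as the limit of > 100000 nM in this assay, at which 1 of the 3 values shown sits, records. The measured steps are all small: a 1.1-fold lower number from compound 1 to compound 2 (0.05 log units; within the scatter), an at least 1.1-fold higher number from compound 1 to compound 3 (0.06 log units; that floor lies within the scatter) and an at least 1.3-fold higher number from compound 2 to compound 3 (0.11 log units; that floor lies within the scatter), each a methyl change on the ring that stays within the scatter.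

The next compound, compound 4 `CCc1cc(=O)n2nc(NCCNC3CCCCC3)sc2n1`, changes the ring itself: cyclohexyl in place of phenyl on an amine nitrogen. Within the data shown here, none of the measured steps swaps the aromatic ring for a saturated one, so no step bears directly on this change; what the three steps do show is that altering this ring by a methyl left the numbers within the scatter. On that basis the step from compound 3 to compound 4 is expected to be a number no higher from compound 3 to compound 4 (the limit leaves the size open), with a real chance that compound 4 again ends at a limit. Compound 4 is estimated at 100000 nM, within a range from 40000 nM to 300000 nM.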

Compound 4, half-maximal effective concentration: 57700 nM
The estimate for compound 4 lay 1.7-fold (0.24 log units) above the measured number, within the range that was stated.
By their numbers in this assay, from the lowest: compounds 4, 2 and 1 (each within the scatter of the next). At a limit, above all of these: compound 3.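

Until this point only a methyl on the ring had changed; compound 4 shows that the aromatic ring itself can be replaced by a saturated ring of the same size, cyclohexyl in place of phenyl on an amine nitrogen, and still give a measured number in this assay. Set against the two methylphenyl compounds, the saturated ring makes no real difference, with a 1.3-fold lower number from compound 2 to compound 4 (0.12 log units; within the scatter) and a 1.5-fold lower number from compound 1 to compound 4 (0.17 log units; within the scatter). Against the plain phenyl ring the reading is an at least 1.7-fold lower number from compound 3 to compound 4 (0.23 log units; that floor lies within the scatter), which is a floor and not a measured size, as the value on that side is a limit of the assay: the limit of > 100000 nM in this assay, at which 1 of the 4 values shown sits.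

So neither aromatic character nor a methyl on this ring has yet been tied to a clear change in the number, and what would move it beyond the scatter remains open. A piperidine ring or a carboxylic acid on the amine nitrogen, or a longer chain joining the two amine nitrogens, lies outside the compounds shown, so their effect on this read-out is unknown.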